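Shortening the alkoxy chain in a sulfonylurea series

This account rests on a few compounds, and the source may have more. Where it says the series, first, only, none or still open, it means among the compounds named here.

Of the compounds shown here, three have been measured in a functional assay on thoracic aorta (Rattus norvegicus, strain Wistar), with a stated time of 15 min; on this read-out higher numbers stand for an effect only at larger amounts of compound and lower numbers for an effect already at smaller amounts. Compound 1 `COc1ccc(Cl)cc1C(C)NC(=O)N(C)S(=O)(=O)c1ccc(Cl)cc1` gives 20000 nM. Compound 2 `CCOc1ccc(Cl)cc1C(C)NC(=O)N(C)S(=O)(=O)c1ccc(Cl)cc1` gives 14600 nM. Compound 3 `CCOc1ccc(Br)cc1C(C)NC(=O)N(C)S(=O)(=O)c1ccccc1` gives 19800 nM; its number lies within the scatter of both compound 1 and compound 2. How the core of compound 3 differs from that of compound 2 is not broken down here.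

The change from compound 2 to compound 1 is hydrogen in place of methyl on a saturated chain carbon bound to an oxygen on an aromatic ring; it made a 1.4-fold higher number from compound 2 to compound 1 (0.14 log units; within the scatter). The same change is now made from compound 3 to compound 4 `COc1ccc(Br)cc1C(C)NC(=O)N(C)S(=O)(=O)c1ccccc1`, as hydrogen in place of methyl on a saturated chain carbon bound to an oxygen on an aromatic ring, at the same place. Among the compounds shown it occurs only twice, so the earlier step is the only guide.

For compound 4 the step is expected to be a 1.2-fold higher number from compound 3 to compound 4 (0.08 log units; within the scatter) in this assay, resting on compound 1 being within the scatter of compound 2 after the same change. The estimate for compound 4 in this assay is 24000 nM, with a range from 12000 nM to 48000 nM.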

Compound 4, half-maximal effective concentration: 16800 nM
Estimate against measurement, compound 4: 1.4-fold (0.15 log units) above; measured number inside the range.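

In this assay the change from ethoxy to methoxy gives a 1.2-fold lower number from compound 3 to compound 4 (0.07 log units; within the scatter) and so stays within the scatter on this core, as it did on the first one. Set side by side, the two steps do not differ in any readable way: the same change on two cores in this assay, a 1.4-fold higher number (0.14 log units; within the scatter) from compound 2 to compound 1 and a 1.2-fold lower number (0.07 log units; within the scatter) from compound 3 to compound 4, 1.6-fold (0.21 log units) apart, within the scatter of two such steps.
This shows that, on the two cores at hand, replacing ethoxy with methoxy leaves the number indistinguishable from that of the parent compound, but it does not show that the change has a real effect of either sign, and the opposite directions of the two steps carry no meaning. Two pairs, both with small steps, also cannot show that this neutrality holds on other cores of the series.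

Open, as far as these compounds go, is how the number responds at this place to a longer chain such as propoxy or butoxy, or to a hydroxyl group or an amine in place of the alkoxy group. The halogens shown never change alone between two compounds, and their separate contribution remains open as well.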